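Hydroxy to Methyl on an Amide Nitrogen

A few compounds are considered here, and "the series" means these few. Any claim that something is new, unique, unknown or untested is made for them only; others in the source may bear on it.

compound 1 `COC(=O)c1cccc(CSc2nc(N)c(C#N)c(-c3ccc(OCC4CC4)cc3)c2C#N)c1`: 4%
compound 2 `N#Cc1c(N)nc(SCn2cncn2)c(C#N)c1-c1ccc(OCC2CC2)cc1`: 1%
compound 3 `N#Cc1c(N)nc(SCC(=O)NO)c(C#N)c1-c1ccc(OCC2CC2)cc1`: 31%

In an assay on CHO cells for displacement of a labelled ligand from adenosine receptor A3 (Homo sapiens), read by scintillation counting, with a stated time of 120 min, tested at 1 uM (a lower number here means less inhibition, a higher number more inhibition at the concentration tested (going by the name of the read-out)), compound 3 stands highest of the three numbers. Its two steps, a number 27 percentage points higher from compound 1 to compound 3 (beyond the scatter) and a number 30 percentage points higher from compound 2 to compound 3 (beyond the scatter), lie beyond the scatter, whereas a number 3 percentage points lower from compound 1 to compound 2 (within the scatter) stays within it. Compound 4 `CNC(=O)CSc1nc(N)c(C#N)c(-c2ccc(OCC3CC3)cc2)c1C#N` differs from compound 3 by methyl in place of hydroxy on an amide-type nitrogen. Among the compounds with values here, no measured step touches this nitrogen; the two steps leading to compound 3 show only that what sits on the saturated chain carbon bound to a sulfur moves the number modestly. A smaller step, probably downward and possibly within the scatter, is therefore expected: a number 13 percentage points lower from compound 3 to compound 4 (beyond the scatter). Compound 4 is estimated at 18%, with a range from 4% to 36%.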

Compound 4, a percentage reported as inhibition, at one concentration (the size of the read-out at that concentration, not a potency): 3%
Estimate against measurement, compound 4: 15 percentage points above, outside the stated range (below it).
By their numbers in this assay, from the lowest: compounds 2, 4 and 1 (each within the scatter of the next); then compound 3.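

Methyl in place of hydroxy on the amide-type nitrogen gives, in this assay, a number 28 percentage points lower from compound 3 to compound 4 (beyond the scatter), so a carbamoyl group on the saturated chain carbon bound to a sulfur does not by itself keep the higher number of compound 3. With methylcarbamoyl there, the number stays close to those of the other two groups: a number 2 percentage points higher from compound 2 to compound 4 (within the scatter) and a number 1 percentage points lower from compound 1 to compound 4 (within the scatter). Nothing measured here explains this drop.

The compounds shown leave open how a hydrogen or a methoxy on this nitrogen would read, and how a carboxylic acid would read in place of hydroxycarbamoyl.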